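Chloro for Hydrogen on a Second Amide Core

The source may report more compounds than this note shows. Statements on the series, on what has been measured and on what is new or still open speak of the compounds shown alone.

Measured so far:
compound 1, `CCN(CC)CCNC(=O)CC(CC(=O)NC1Cc2ccccc2C1)c1ccc(Cl)cc1`: > 100000 nM
compound 2, `CCN(CC)CCNC(=O)CC(CC(=O)NC1Cc2ccccc2C1)c1ccccc1`: > 100000 nM
compound 3, `CN(C(=O)CC(CC(=O)NCCN1CCCC1)c1ccccc1)C1Cc2ccccc2C1`: > 100000 nM

Compound 2 carries a plain phenyl on the shared core. In a functional assay on MGC-803 cells (Homo sapiens) for inhibition (a higher number here means a weaker inhibitor, a lower number a stronger inhibitor), compound 2 gives > 100000 nM, which is a limit of the assay and not a number. Compound 1 carries the change chloro in place of hydrogen on an aromatic carbon on the same core. In this assay compound 1 gives > 100000 nM, again a limit. The change therefore yields a step that the two limits leave unreadable from compound 2 to compound 1. What the three values have in common is the limit of > 100000 nM in this assay, at which 3 of the 3 values shown sit.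

Compound 3 rests on a different core; how that core differs from the core of compound 2 is not broken down here. In this assay compound 3 gives > 100000 nM, which is a limit as well.

Compound 4, `CN(C(=O)CC(CC(=O)NCCN1CCCC1)c1ccc(Cl)cc1)C1Cc2ccccc2C1`, has not been measured. It stands to compound 3 as compound 1 stands to compound 2: the change is chloro in place of hydrogen on an aromatic carbon, the same change in the same place. Because compound 3 sits at > 100000 nM and because the same change produced a step that the two limits leave unreadable from compound 2 to compound 1, the step to compound 4 is expected to be a step that the limit leaves unreadable from compound 3 to compound 4. The estimate for compound 4 in this assay is 150000 nM, with an expected range from 50000 nM to 500000 nM, and most likely the assay will once more report only a limit for compound 4 rather than a number.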

Compound 4, half-maximal inhibitory concentration: 83800 nM
For compound 4 the middle estimate is 1.8-fold (0.25 log units) above the measured one, within the range that was stated.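

Among these compounds, on the second core, the change from phenyl to 4-chlorophenyl gives in this assay an at least 1.1-fold lower number from compound 3 to compound 4 (0.07 log units; that floor lies within the scatter), so the new step shows no change beyond the scatter, even though compound 4 is the only one of the four compounds with a number rather than a limit. The steps on the core of compound 2 and between limits cannot be read, so the effect of the same change on the two cores cannot be set side by side. The result therefore neither shows that the change carries from one core to the other nor shows that it fails to, because the comparison is held back by the ceiling of the assay: the limit of > 100000 nM in this assay, at which 3 of the 4 values shown sit.

From the compounds shown here alone, what stays open is whether a bromo or a methoxy group, on the same aromatic carbon in place of the chloro, would give a step beyond the scatter in this assay on either core. Also open, going by these compounds, is whether a longer chain leading to the amine, or a carboxylic acid in place of that amine, would bring the compounds on either core clear of the limit and allow the two cores to be compared.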